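A few compounds are considered here, and "the series" means these few. Any claim that something is new, unique, unknown or untested is made for them only; others in the source may bear on it.

Compound 1 `CCCCN1CCC(C(=O)Nc2cc(Cl)c(N)cc2OC)CC1`: in a functional assay on the whole organism for antagonist activity, with Mus musculus as the target (on this read-out lower numbers stand for an effect already at smaller amounts and higher numbers for an effect only at larger amounts of compound), compound 1 gives > 10 mg/kg, which is a limit of the assay and not a number.
Compound 2 `COc1cc(N)c(Cl)cc1NC(=O)C1CCN(Cc2ccccc2F)CC1`: in this assay compound 2 gives > 4 mg/kg, again only a limit.
Compound 3 `COc1cc(N)c(Cl)cc1NC(=O)C1CCN(Cc2ccc(C)c(C)c2)CC1`: in this assay compound 3 gives > 8 mg/kg, also only a limit.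

Compound 3 therefore stands nowhere definite on the numbers shown: its own value is a limit, and the two further values are limits as well, as the limit of > 10 mg/kg in this assay, at which 1 of the 3 values shown sits, the limit of > 4 mg/kg in this assay, at which 1 of the 3 values shown sits, and the limit of > 8 mg/kg in this assay, at which 1 of the 3 values shown sits, record. The three steps among the measured compounds, a step that the two limits leave unreadable from compound 1 to compound 2, a step that the two limits leave unreadable from compound 1 to compound 3 and a step that the two limits leave unreadable from compound 2 to compound 3, all change the group on the saturated chain carbon bound to the amine nitrogen in the ring, and none of them can be read in size or direction.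

Compound 4 `COc1cc(N)c(Cl)cc1NC(=O)C1CCN(Cc2cccc(Cl)c2)CC1` differs from compound 3 by 3-chlorophenyl in place of 3,4-dimethylphenyl on a saturated chain carbon bound to an amine nitrogen in a ring. The same kind of change in the same place is what the three unreadable steps cover, so nothing beyond the scatter can be expected or excluded, and the step is estimated as a step that the limit leaves unreadable from compound 3 to compound 4. Compound 4 is expected to come out at 10 mg/kg, within 3 mg/kg to 30 mg/kg, with a real chance that only a limit is reported again.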

Compound 4, dose for half-maximal effect: > 4 mg/kg
Compound 4: a limit, no number; the forecaster's own chance of this, stated with the estimate: 65%; the middle value is on the limit's open side.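

Compound 4 again gives only a limit, and its steps from compound 1, compound 2 and compound 3 cannot be read in size or direction. The compounds shown leave open whether any of these groups on the saturated chain carbon has a measurable effect in this assay, and how the groups rank.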